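The source may report more compounds than this note shows. Statements on the series, on what has been measured and on what is new or still open speak of the compounds shown alone.

Compound 2 `Cc1ccc2oc(SCC(=O)Nc3ccc(-c4nc(-c5ccccc5)c(-c5ccccc5)n4C)cc3)nc2c1` is the stronger of the two compounds measured in a functional assay on HT-29 cells (Homo sapiens) for cytotoxicity, read by MTT assay, with a stated time of 24 h, tested at 16 ug/mL; a higher number here means a stronger effect of the compound at the concentration tested, a lower number a weaker effect. Compound 2 gives 37.7%, while its nearest neighbour, compound 1 `Cn1c(-c2ccc(NC(=O)CCl)cc2)nc(-c2ccccc2)c1-c1ccccc1`, gives 23.7%. Among the compounds with values here, the two differ in a single spot on the chain beside the carbonyl, and that difference is the only measured step so far.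

Compound 3 `Cn1c(-c2ccc(NC(=O)CSc3nc4ccccc4s3)cc2)nc(-c2ccccc2)c1-c1ccccc1` has not been measured. Compared with compound 2 it carries 1,3-benzothiazol-2-yl in place of 5-methyl-1,3-benzoxazol-2-yl on a sulfur. The ring system on the sulfur is exchanged, while the rest of the molecule stays the same.

Within the data shown here, the one measured step concerns a different exchange at this end of the molecule: a number 14 percentage points higher from compound 1 to compound 2 (beyond the scatter) came from putting the whole (5-methyl-1,3-benzoxazol-2-yl)sulfanyl group in place of a chloro. No measurement shows how 1,3-benzothiazol-2-yl compares with 5-methyl-1,3-benzoxazol-2-yl on that sulfur. Since what is counted changes little, the expected step in this assay is a number 0.3 percentage points higher from compound 2 to compound 3 (within the scatter), not beyond the scatter. Compound 3 is therefore estimated to give about 38%, most likely between 22% and 55%.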

Compound 3, a percentage reported as activity, at one concentration (the size of the read-out at that concentration, not a potency): 47.2%
Beside the measured number, compound 3's estimate is 9.2 percentage points below it; measured number inside the range.
By their numbers in this assay, from the lowest: compound 1; then compounds 2 and 3 (each within the scatter of the next).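

In this assay, exchanging the ring system on the sulfur gives a number 9.5 percentage points higher from compound 2 to compound 3 (within the scatter) so these numbers do not separate 1,3-benzothiazol-2-yl from 5-methyl-1,3-benzoxazol-2-yl, even though the two differ in their heavy atom count and the entering group holds a sulfur where the leaving group holds an oxygen. Putting (1,3-benzothiazol-2-yl)sulfanyl in place of chloro on the saturated chain carbon bound to a carbonyl carbon gives a number 23.5 percentage points higher from compound 1 to compound 3 (beyond the scatter) so a second ring system on the sulfur also stands clear of the chloro compound, and the earlier gain over compound 1 is no longer tied to a single group. No measured evidence here explains what lies behind either step.

Going by these compounds, whether the ring system is needed at all remains open, as does the effect of a small amine or a carboxylic acid on the saturated chain carbon in place of the sulfur-linked group. A longer chain between the carbonyl and the sulfur is also untested among the compounds shown, so the reach of this end of the molecule is still unknown.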